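The compounds below may be only part of what the source reports. "The series", "measured", "known", "first", "only" and "open" are said of these compounds alone.

Of the compounds shown here, three have been measured in a functional assay, read by spectrophotometry, with a stated time of 30 min (a higher number here means a weaker inhibitor, a lower number a stronger inhibitor), and a fourth awaits its number. Compound 1, `CCCC/N=C/c1cc2cc(C)ccc2[nH]c1=O`, gives 63200 nM in this assay. Compound 2, `Cc1ccc2[nH]c(=O)c(/C=N/Nc3ccccc3)cc2c1`, gives 62400 nM in this assay. Compound 3, `CCCC/N=C/c1cc2ccccc2[nH]c1=O`, gives 439000 nM in this assay. The step of a 1.0-fold lower number from compound 1 to compound 2 (0.01 log units; within the scatter) lies within the scatter, so the two numbers cannot be told apart, and the two cores differ by anilino in place of butyl on a double-bonded nitrogen. The step of a 6.9-fold higher number from compound 1 to compound 3 (0.84 log units; beyond the scatter) is beyond the scatter and is described as modest; it corresponds to hydrogen in place of methyl on an aromatic carbon.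

Compound 4, `O=c1[nH]c2ccccc2cc1/C=N/Nc1ccccc1`, has not yet been measured in this assay. It differs from compound 2 by hydrogen in place of methyl on an aromatic carbon. This is the same change that separates compound 1 from compound 3, the place being described in the same words for both pairs, and it occurs twice among the compounds shown. Within the data shown here, the only measured instance of this change is a 6.9-fold higher number from compound 1 to compound 3 (0.84 log units; beyond the scatter). Since the core of compound 2 and the core of compound 1 gave numbers within the scatter of each other, the step from compound 2 to compound 4 is expected to resemble that earlier one. The estimated step is therefore a 6.9-fold higher number from compound 2 to compound 4 (0.84 log units; beyond the scatter). For compound 4 the expected value in this assay is 430000 nM, with the likely range estimated from 150000 nM to 1200000 nM.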

Compound 4, half-maximal inhibitory concentration: 76500 nM
Beside the measured number, compound 4's estimate is 5.6-fold (0.75 log units) above it; measured number outside the range, below it.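

In this assay, hydrogen in place of methyl on an aromatic carbon gives a 1.2-fold higher number from compound 2 to compound 4 (0.09 log units; within the scatter), so with anilino on the double-bonded nitrogen the change leaves no effect that can be read. The same change therefore does not carry over as one fixed step between the two cores, and the instances disagree by more than their scatter allows: the same change on two cores in this assay, a 6.9-fold higher number (0.84 log units; beyond the scatter) from compound 1 to compound 3 and a 1.2-fold higher number (0.09 log units; within the scatter) from compound 2 to compound 4, 5.7-fold (0.75 log units) apart, beyond the scatter of two such steps. This shows that, in this series, a step seen with butyl on the double-bonded nitrogen cannot simply be transferred to the anilino core, but two pairs do not show why the steps part, nor which of them is the more usual outcome.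

The compounds shown leave open how other groups at that aromatic carbon, such as chlorine or methoxy, would behave on either core, and whether they would separate the two cores as methyl and hydrogen do. They also leave open whether a longer chain or a benzylamino group on the double-bonded nitrogen would follow the butyl pair, the anilino pair or neither.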